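Replacing the 4-Methoxyphenyl Group of Compound 3

A few compounds are considered here, and "the series" means these few. Any claim that something is new, unique, unknown or untested is made for them only; others in the source may bear on it.

Measured so far in a functional assay on HepG2 cells (Homo sapiens) for antiproliferative activity, read by MTT assay, with a stated time of 72 h; on this read-out lower numbers stand for stronger inhibition and higher numbers for weaker inhibition
- compound 1 `O=C(N/N=C/c1cccc(Br)c1)Nc1ccc(Oc2ccnc3[nH]ccc23)c(F)c1` gives 660 nM
- compound 2 `O=C(N/N=C/c1ccc([N+](=O)[O-])cc1)Nc1ccc(Oc2ccnc3[nH]ccc23)c(F)c1` gives 3030 nM
- compound 3 `COc1ccc(/C=N/NC(=O)Nc2ccc(Oc3ccnc4[nH]ccc34)c(F)c2)cc1` gives 1770 nM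

Compound 3 stands with compound 2 at the upper end of these numbers: a 1.7-fold lower number from compound 2 to compound 3 (0.23 log units; within the scatter) stays within the scatter, while a 2.7-fold higher number from compound 1 to compound 3 (0.43 log units; beyond the scatter) goes beyond it. Compound 4 `O=C(N/N=C/c1cc(Br)c(O)c(Br)c1)Nc1ccc(Oc2ccnc3[nH]ccc23)c(F)c1` differs from compound 3 on the carbon with a double bond to nitrogen, as follows (3,5-dibromo-4-hydroxyphenyl in place of 4-methoxyphenyl on a carbon with a double bond to nitrogen). Only compound 1 already carries bromine there, and both steps away from it, a 4.6-fold higher number from compound 1 to compound 2 (0.66 log units; beyond the scatter) and a 2.7-fold higher number from compound 1 to compound 3 (0.43 log units; beyond the scatter), were modest. For the measured compounds named here, no measured compound carries a hydroxy group, so that part remains open. In this assay a modest drop is therefore expected, an estimated 2.2-fold lower number from compound 3 to compound 4 (0.34 log units; beyond the scatter). Compound 4 is estimated at 800 nM, with an expected range of 250 nM to 2500 nM.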

Compound 4, half-maximal inhibitory concentration: 6520 nM
The estimate for compound 4 lay 8.2-fold (0.91 log units) below the measured number; measured number above the stated range.
By their numbers in this assay, from the lowest: compound 1; then compounds 3 and 2 (each within the scatter of the next); then compound 4.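

In this assay, the 3,5-dibromo-4-hydroxyphenyl group gives the highest number of the four compounds (a 3.7-fold higher number from compound 3 to compound 4 (0.57 log units; beyond the scatter)) (a 2.2-fold higher number from compound 2 to compound 4 (0.33 log units; beyond the scatter)) (a 9.9-fold higher number from compound 1 to compound 4 (0.99 log units; beyond the scatter)), each step beyond the scatter. Bromine on this group therefore does not by itself keep the number low: compound 1 has the lowest number and compound 4 the highest. Nothing available explains this rise.

The compounds shown do not separate the effect of the hydroxy group from that of the two bromines. On these data alone, how an amine or a carboxylic acid on this phenyl group would read also stays open.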